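Lipophilicity notes: styryl replacement on the thiazolidinone core

The compounds below may be only part of what the source reports. "The series", "measured", "known", "first", "only" and "open" are said of these compounds alone.

Measured so far:
compound 1 `O=C(CN1C(=O)c2ccccc2C1=O)NN1C(=O)CSC1c1ccc(O)cc1`: 2.4
compound 2 `Cc1ccc(C2SCC(=O)N2NC(=O)CN2C(=O)c3ccccc3C2=O)cc1`: 2.97

In a physicochemical assay for lipophilicity, in phosphate buffer, measured as octanol-water partition, with a stated time of 24 h (on this read-out lower numbers stand for lower lipophilicity and higher numbers for higher lipophilicity), compound 1 gives 2.4, the lowest of the two numbers; the nearest is compound 2, and the step of a number 0.57 log units higher from compound 1 to compound 2 (beyond the scatter) is beyond the scatter.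

Compound 3 `O=C(CN1C(=O)c2ccccc2C1=O)NN1C(=O)CSC1/C=C/c1ccccc1` is not yet measured. It differs from compound 1 in one place: 2-phenylethenyl in place of 4-hydroxyphenyl on a saturated ring carbon

Within the data shown here, only one measured step bears on this change, the methyl-for-hydroxy step a number 0.57 log units higher from compound 1 to compound 2 (beyond the scatter), which removes the same hydroxy group; no measured pair shows the effect of the phenylethenyl itself. Since that step was modest and upward, and the entering group is larger and carries no donor or acceptor, an upward step beyond the scatter is expected for compound 3, and the estimated step of a number 1.10 log units higher from compound 1 to compound 3 (beyond the scatter) is placed somewhat larger than the methyl step. In this assay compound 3 is therefore expected to give about 3.5, within 3 to 4.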

Compound 3, partition coefficient: 3.65
For compound 3 the middle estimate is 0.15 log units below the measured one, within the range that was stated.
By their numbers in this assay, from the lowest: compound 1; then compound 2; then compound 3.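

In this assay, the saturated ring carbon tolerates replacement of the whole aryl group, not only of its hydroxy: 2-phenylethenyl in place of 4-hydroxyphenyl gives a number 1.25 log units higher from compound 1 to compound 3 (beyond the scatter) as a large step. The same entering group in place of 4-methylphenyl still gives a number 0.68 log units higher from compound 2 to compound 3 (beyond the scatter) as a modest step, so the rise at this position does not depend only on losing the hydroxy, which was all the earlier pair could show. No measurement at hand accounts for either step.

The compounds shown do not separate the double bond outside the aromatic ring from the change in carbon count, and a saturated 2-phenylethyl group at this carbon would bear on that. On these data alone, how the read-out responds to an amine or a carboxylic acid on the aromatic ring also remains open.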